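The source may hold more compounds than are shown below. What is called first, only, known or untested is meant among the compounds shown, and "the series" means these compounds.

Measured so far:
- compound 1, `O=C(O)/C(S)=C/c1ccc(Cl)cc1`: 2600 nM
- compound 2, `O=C(O)/C(S)=C/c1cccc(F)c1`: 19000 nM
- compound 3, `O=C(O)/C(S)=C/c1c[nH]c2ccc(I)cc12`: 100 nM

All three numbers come from an assay on isolated protein for inhibition of Calpain-1 catalytic subunit (Sus scrofa), read by FRET; a higher number here means a weaker inhibitor, a lower number a stronger inhibitor. Compound 3 stands lowest of the three, and its separation from the others is beyond the usual scatter in both cases: compound 1 is the nearest, compound 2 the furthest. On these numbers compound 3 is the strongest inhibitor in this assay. Compounds 1 and 2 differ from each other in more than one place, so their two values are noted side by side without further comparison.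

Compound 4, `O=C(O)/C(S)=C/c1c[nH]c2ccc(Cl)cc12`, has not yet been measured in this assay. It differs from compound 3 in one place: chloro in place of iodo on an aromatic carbon. For the measured compounds named here, no measured pair in the set isolates this particular change, so the size of the step is not anchored by a precedent here. The expectation is a modest move toward a higher number, most likely within or just beyond the scatter, with the step expected to be a 2.5-fold higher number from compound 3 to compound 4 (0.40 log units; beyond the scatter). Compound 4 is accordingly estimated at 250 nM in this assay, with a range from 90 nM to 700 nM.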

Compound 4, half-maximal inhibitory concentration: 250 nM
The estimate for compound 4 equals the measured number at the digits printed, and the stated range covers the measured number.
By their numbers in this assay, from the lowest: compound 3; then compound 4; then compound 1; then compound 2.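

In this assay, for the compounds shown here, chloro in place of iodo on an aromatic carbon of the six-membered ring of carbon only gives a 2.5-fold higher number from compound 3 to compound 4 (0.40 log units; beyond the scatter), the first step that can be read at a single place. Compounds 1 and 2 could only be set side by side, whereas this pair shows that the number responds to which halogen sits at this position, with the rest of the shared core held fixed. The step is modest but lies beyond the scatter, so the exchange of one halogen for the other at this carbon costs some inhibition without abolishing it, and nothing measured here bears on what lies behind the shift.

As far as these compounds go, with only iodo and chloro compared at this carbon, it remains open whether fluoro, a methoxy group, an amine or a nitrile there would give a number closer to that of compound 3 or further from it. Also open, from the compounds shown here alone, is whether a step of this size would hold on a changed core, for example with a methyl ester in place of the carboxylic acid.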